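This account rests on a few compounds, and the source may have more. Where it says the series, first, only, none or still open, it means among the compounds named here.

- Compound 1 `COc1ccc(/C=C/C(=O)Nc2cc3c(Nc4ccc(Cl)c(Cl)c4)ncnc3s2)cc1`: 790 nM
- Compound 2 `O=C(/C=C/c1ccccc1)Nc1cc2c(Nc3ccc(Cl)c(Cl)c3)ncnc2s1`: 480 nM

Among the measured compounds shown here, in a functional assay on PC-3 cells (Homo sapiens) for antiproliferative activity, read by MTT assay, with a stated time of 48 h (on this read-out higher numbers stand for weaker inhibition and lower numbers for stronger inhibition), compound 1 gives 790 nM, and no clear order separates the two measured compounds: the only measured step is a 1.6-fold lower number from compound 1 to compound 2 (0.22 log units; within the scatter).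

Compound 3 `COc1ccc(/C=C/C(=O)Nc2cc3c(Nc4cc(Cl)cc(Cl)c4)ncnc3s2)cc1` differs from compound 1 elsewhere: 3,5-dichlorophenyl in place of 3,4-dichlorophenyl on a nitrogen on an aromatic ring. Here 3,5-dichlorophenyl stands in place of 3,4-dichlorophenyl on a nitrogen on an aromatic ring. The measured step concerns hydrogen in place of methoxy, so it offers no direct guide to this change, and no direction can be argued from the data. The expected step is therefore small: a 1.1-fold higher number from compound 1 to compound 3 (0.06 log units; within the scatter). For compound 3 the estimate is 900 nM, with an expected range of 280 nM to 2800 nM.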

Compound 3, half-maximal inhibitory concentration: 450 nM
For compound 3 the middle estimate is 2.0-fold (0.30 log units) above the measured one; the range from low to high includes it.
By their numbers in this assay, from the lowest: compounds 3, 2 and 1 (each within the scatter of the next).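

In this assay, 3,5-dichlorophenyl in place of 3,4-dichlorophenyl on the nitrogen gives a 1.8-fold lower number from compound 1 to compound 3 (0.24 log units; within the scatter) for this first change at this position. The two groups have the same atoms joined differently, and this assay does not separate them, so the two chlorine patterns cannot be ranked here. No measurement shown gives a reason for this result.

Still open, on these data alone, is whether a plain phenyl or a pyridine ring on that nitrogen would give a number beyond the scatter. Also open, as far as these compounds go, is how hydrogen in place of methoxy would read alongside 3,5-dichlorophenyl.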